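The source may report more compounds than this note shows. Statements on the series, on what has been measured and on what is new or still open speak of the compounds shown alone.

Compound 3 `COCc1ncnc2c1ncn2[C@@H]1O[C@H](CO)[C@@H](O)[C@H]1O` belongs to a set of three compounds with a shared core that were examined in a functional assay on Huh-7 cells (Homo sapiens) for cytotoxicity, read by MTT assay, with a stated time of 3 days; a higher number here means that more compound is tolerated, a lower number that less compound is tolerated. In this assay compound 3 gives > 100000 nM, which is a limit of the assay and not a number. Compound 1 `CC(=O)N(Cc1ccccc1)Cc1ncnc2c1ncn2[C@@H]1O[C@H](CO)[C@@H](O)[C@H]1O` gives > 100000 nM, again a limit. Compound 2 `OC[C@H]1O[C@@H](n2cnc3c(CSCc4ccccc4)ncnc32)[C@H](O)[C@@H]1O` gives > 100000 nM, also a limit. The step that the two limits leave unreadable from compound 2 to compound 3 cannot be read since the limit of > 100000 nM in this assay, at which 3 of the 3 values shown sit, holds every value shown. Compound 4 `OC[C@H]1O[C@@H](n2cnc3c(CN4CCCCC4)ncnc32)[C@H](O)[C@@H]1O` differs from compound 3 by piperidin-1-yl in place of methoxy on a saturated chain carbon bound to an aromatic carbon. Going by the values given here, no measured step bears on this change, so no shift beyond the scatter is expected, and the step of a number no higher from compound 3 to compound 4 (the limit leaves the size open) is estimated as flat. Compound 4 is accordingly expected to give 100000 nM, within a range from 50000 nM to 300000 nM.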

Compound 4, half-maximal cytotoxic concentration: 87000 nM
Compound 4: the middle estimate sits 1.1-fold (0.06 log units) above what was measured, within the range that was stated.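

In this assay compound 4 is the only compound shown that gives a number and not a limit, so piperidin-1-yl is the first group on this saturated chain carbon bound to an aromatic carbon with a readable value. The change from methoxy reads as an at least 1.1-fold lower number from compound 3 to compound 4 (0.06 log units; that floor lies within the scatter) and the change from benzylsulfanyl as an at least 1.1-fold lower number from compound 2 to compound 4 (0.06 log units; that floor lies within the scatter) and so neither step shows a shift beyond the scatter. The remaining step cannot be read: the limit of > 100000 nM in this assay, at which 3 of the 4 values shown sit. The compounds shown leave open whether a primary amine or a carboxylic acid at this place would give a number clearly apart from that of compound 4. From the compounds shown here alone, the actual values of compound 2 and compound 3 also stay open.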